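The compounds below may be only part of what the source reports. "The series", "measured", "known", "first", "only" and "open" are said of these compounds alone.

In a functional assay on Hs-578T cells (Homo sapiens) for inhibition, read by sulforhodamine B assay, with a stated time of 48 h, tested at 10 uM (a higher number here means more inhibition at the concentration tested (going by the name of the read-out), a lower number less inhibition), compound 1 `Clc1ccc(-c2cn3ccnc3c(-c3ccc4ncn(C5CCCCC5)c4c3)n2)cc1` gives 6.35%, compound 2 `Brc1ccc(-c2cn3ccnc3c(-c3ccc4ncn(C5CCCCC5)c4c3)n2)cc1` gives 24.5%, and compound 3 `CCc1ccc(-c2cn3ccnc3c(-c3ccc4ncn(Cc5ccccc5)c4c3)n2)cc1` gives 21.8%. Compound 3 thus stands second highest of the three measured numbers: the value of compound 2 lies within the usual scatter of it, whereas the value of compound 1 lies beyond the scatter and lower.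

Among the measured compounds shown here, only one step between measured compounds differs in a single place, a number 18.2 percentage points higher from compound 1 to compound 2 (beyond the scatter), and it shows that exchanging one group on the phenyl ring attached to the shared core can move the number by a modest amount. Compound 4 `Cc1cccc(-c2cn3ccnc3c(-c3ccc4ncn(Cc5ccccc5)c4c3)n2)c1` differs from compound 3 in one place: 3-methylphenyl in place of 4-ethylphenyl on an aromatic carbon. For the measured compounds named here, no measured step swaps one carbon-only group on this phenyl ring for another, so the bromo-for-chloro step offers only a loose guide. Since the two rings that leave and enter carry no donors, no acceptors and no charge, and differ in one heavy atom, the expectation is a step of no clear direction, most likely within the scatter, as a number 3.8 percentage points lower from compound 3 to compound 4 (within the scatter).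

The estimate for compound 4 in this assay is therefore 18%, with a range from 5% to 32%.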

Compound 4, a percentage reported as inhibition, at one concentration (the size of the read-out at that concentration, not a potency): 8.47%
Beside the measured number, compound 4's estimate is 9.5 percentage points above it, and the stated range covers the measured number.
By their numbers in this assay, from the lowest: compounds 1 and 4 (each within the scatter of the next); then compounds 3 and 2 (each within the scatter of the next).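

In this assay, placing 3-methylphenyl where 4-ethylphenyl stood gives a number 13.3 percentage points lower from compound 3 to compound 4 (beyond the scatter) and so lies beyond the usual scatter, even though both groups are carbon-only rings with no hydrogen-bond donors, no hydrogen-bond acceptors and no net charge. Among the compounds shown here, the only earlier step on this ring was the exchange of chloro for bromo, a number 18.2 percentage points higher from compound 1 to compound 2 (beyond the scatter) and the new step shows that the number at this position can also shift clearly when only a carbon-only group changes, so such a swap cannot be assumed to leave the inhibition as it was. Nothing measured here explains why the number falls, so the result stands as an observation without an explanation.

This single step changes two things at once, the length of the chain on the phenyl ring and the place where that chain sits, and it cannot show which of them matters. The compounds shown leave that question open, which 4-methylphenyl or 3-ethylphenyl could help to settle, and they also leave open how this position would respond to a ring carrying an amine or a carboxylic acid.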